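A few compounds are considered here, and "the series" means these few. Any claim that something is new, unique, unknown or untested is made for them only; others in the source may bear on it.

Compound 1 `CC(C)Cc1cc(-c2cccc(Cn3ccnc3)c2)c(S(=O)(=O)NC(=O)OC(C)C)s1` gives 160 nM in an assay on HEK293 cells for displacement of a labelled ligand from Type-2 angiotensin II receptor (Homo sapiens), read by scintillation counting, with a stated time of 240 min; a higher number here means a weaker inhibitor, a lower number a stronger inhibitor. Compound 2 `CC(C)CCOC(=O)NS(=O)(=O)c1sc(CC(C)C)cc1-c1cccc(Cn2ccnc2)c1` gives 230 nM in this assay; of the two numbers shown, compound 2 holds the larger, but a 1.4-fold higher number from compound 1 to compound 2 (0.16 log units; within the scatter) lies within the scatter, so neither compound can be called the stronger. Compound 3 `CCN(CC)C(=O)NS(=O)(=O)c1sc(CC(C)C)cc1-c1cccc(Cn2ccnc2)c1` differs from compound 2 in one place: diethylamino in place of isopentyloxy on a carbonyl carbon. Among the compounds with values here, no measured step touches a change of this kind. Within the data shown here, the single step in hand, a 1.4-fold higher number from compound 1 to compound 2 (0.16 log units; within the scatter), exchanged one chain for another on the isopentyloxy side and left the number essentially unmoved, and it cannot settle what putting diethylamino in place of isopentyloxy on the carbonyl carbon will do. Compound 3 is therefore expected to land near compound 2, with a step of a 1.3-fold higher number from compound 2 to compound 3 (0.12 log units; within the scatter) that may fall either side of the scatter. The estimate for compound 3 in this assay is 300 nM, within 100 nM to 1000 nM.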

Compound 3, inhibition constant: 2300 nM
For compound 3 the middle estimate is 7.7-fold (0.88 log units) below the measured one, and the stated range ends below it.
By their numbers in this assay, from the lowest: compounds 1 and 2 (each within the scatter of the next); then compound 3.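

Compound 1 and compound 2 had shown only that isopropoxy and isopentyloxy on a carbonyl carbon read alike in this assay (a 1.4-fold higher number from compound 1 to compound 2 (0.16 log units; within the scatter)), which said nothing about a change of the group's linking atom. Diethylamino on that carbonyl carbon shows that this position is not indifferent to every exchange: the number climbs beyond the scatter against isopentyloxy (a 10-fold higher number from compound 2 to compound 3 (1.00 log units; beyond the scatter)) and against isopropoxy (a 14-fold higher number from compound 1 to compound 3 (1.16 log units; beyond the scatter)), leaving compound 3 the weakest of the three. Nothing available gives a reason for this loss.

From the compounds shown here alone, it remains open whether ethylamino or a cyclic amine such as pyrrolidine on the carbonyl carbon would follow diethylamino or the alkoxy groups. Going by these compounds, it is also open whether a simple alkyl chain placed directly on that carbonyl carbon would read closer to compound 2 or compound 3.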